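Removing the acetyl from the thiazole amine

This account rests on a few compounds, and the source may have more. Where it says the series, first, only, none or still open, it means among the compounds named here.

Compound 1, `CCCCCCC#Cc1ccc(S(=O)(=O)Nc2cccc(-c3csc(NC(C)=O)n3)c2)cc1`: 12.8%
Compound 2, `CC(=O)Nc1nc(-c2cccc(NS(=O)(=O)c3ccc(C#C[Si](C)(C)C)cc3)c2)cs1`: 4.2%
Compound 3, `CCCCCCCCc1ccc(S(=O)(=O)Nc2cccc(-c3csc(NC(C)=O)n3)c2)cc1`: < 1% (a limit)

In a functional assay on A-375 cells (Homo sapiens) for antiproliferative activity, read by trypan blue exclusion, with a stated time of 48 h, tested at 5 uM (on this read-out lower numbers stand for a stronger effect and higher numbers for a weaker effect at the one concentration tested), compound 1 gives 12.8%, the higher of the two numbers reported as numbers. Compound 2 stands nearest, with a number 8.6 percentage points lower from compound 1 to compound 2 (within the scatter). For compound 3 the reported < 1% is a limit of the assay and not a number, so its distance from the others is known only as a floor (the limit of < 1% in this assay, at which 1 of the 3 values shown sits).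

The untested compound 4, `CCCCCCC#Cc1ccc(S(=O)(=O)Nc2cccc(-c3csc(N)n3)c2)cc1`, differs from compound 1 in one place: hydrogen in place of acetyl on a nitrogen on an aromatic ring. For the measured compounds named here, none of the measured steps touches that nitrogen. They all concern the other end of the shared core: a number at least 11.8 percentage points lower from compound 1 to compound 3 (beyond the scatter), and a number at least 3.2 percentage points lower from compound 2 to compound 3 (that floor lies within the scatter). Going by the values given here, they therefore say nothing about what the loss of the acetyl does, and the only anchor is compound 1 itself, whose 12.8% is taken as the starting point. Among the compounds with values here, with no measured step bearing on the change, the expectation is for no step beyond the scatter in either direction, held with wide bounds.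

Compound 4 is therefore expected to give about 15%, between 3% and 40%. The expected step is then a number 2.2 percentage points higher from compound 1 to compound 4 (within the scatter).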

Compound 4, a percentage reported as activity, at one concentration (the size of the read-out at that concentration, not a potency): < 1%
Compound 4 gave a limit, no number (the forecaster's own chance of this, stated with the estimate: 10%); middle value at least 14 percentage points away from the limit.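

In this assay, the change from acetamido to amino gives a number at least 11.8 percentage points lower from compound 1 to compound 4 (beyond the scatter). For the compounds shown here, this is the first evidence that the read-out responds to a change at this nitrogen on the aromatic ring, since the earlier steps all concerned the other end of the shared core, and it shows that the acetyl is not needed for the effect at the one concentration tested. Compound 4 gives < 1%, which is a limit of the assay and not a number, so the step has a floor but no known size, and any further gain at this nitrogen could not be read from this value: the limit of < 1% in this assay, at which 2 of the 4 values shown sit.

The compounds shown leave open whether it is the loss of the acetyl as such that matters, as a methyl or a propanoyl on the same nitrogen, or a urea in place of the acetamido, would begin to tell. They also leave open whether the amino group gives a similar step alongside an octyl chain or a trimethylsilyl-capped alkyne at the other end of the shared core.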